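Adding a Cyano Group to Compound 2

The source may report more compounds than this note shows. Statements on the series, on what has been measured and on what is new or still open speak of the compounds shown alone.

Of the compounds shown here, two sharing one core have been measured in a functional assay on MCF7 cells (Homo sapiens) for cytotoxicity, read by CellTiter-Glo, with a stated time of 5 days; on this read-out lower numbers stand for stronger inhibition and higher numbers for weaker inhibition. Compound 1 `CC/C(=C(\c1ccc2[nH]ncc2c1)c1ccc(/C=C/C(=O)O)cc1OC)c1ccccc1` gives 12 nM in this assay. Compound 2 `CC/C(=C(/c1ccc(/C=C/C(=O)O)cc1)c1ccc2[nH]ncc2c1)c1ccccc1Cl` gives 2 nM in this assay, the lower of the two numbers, and its gap to compound 1 lies beyond the scatter. Compound 3 `CC/C(=C(/c1ccc(/C=C/C(=O)O)cc1)c1ccc2[nH]ncc2c1)c1ccc(C#N)cc1Cl` differs from compound 2 by cyano in place of hydrogen on an aromatic carbon. For the measured compounds named here, no pair of measured compounds differing in one place exists, so there is no direct precedent for this change. A step within the scatter is expected, in either direction, a 1.5-fold higher number from compound 2 to compound 3 (0.18 log units; within the scatter). Compound 3 is estimated at 3 nM, between 1 nM and 10 nM.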

Compound 3, half-maximal inhibitory concentration: 4 nM
Compound 3: the middle estimate sits 1.3-fold (0.12 log units) below what was measured; the range from low to high includes it.
By their numbers in this assay, from the lowest: compounds 2 and 3 (each within the scatter of the next); then compound 1.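

For the compounds shown here, with this assay as the read-out, a step of a 2.0-fold higher number from compound 2 to compound 3 (0.30 log units; within the scatter) is the first comparison here of compounds that differ in one place. It shows that this aromatic carbon, meta to a chloro group and para to a large group, takes cyano in place of hydrogen with no difference that stands clear of the scatter. The change from 2-chlorophenyl to 2-chloro-4-cyanophenyl therefore leaves the value in the same range as that of compound 2, at 2 nM in this read-out.

From the compounds shown here alone, whether an amine or a trifluoromethyl group on the same carbon would read alike remains open. Nothing at hand gives a measured reason for this result.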